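Propargylic enol ether esters: alkyl branch at the propargylic carbon

A few compounds are considered here, and "the series" means these few. Any claim that something is new, unique, unknown or untested is made for them only; others in the source may bear on it.

In a functional assay on SW1573 cells (Homo sapiens) for antiproliferative activity, read by sulforhodamine B assay, with a stated time of 48 h (on this read-out lower numbers stand for stronger inhibition of growth and higher numbers for weaker inhibition of growth), compound 1 `COC(=O)C#CC(CC(C)C)O/C=C/C(=O)OC` gives 380 nM, the lowest of the two numbers in the set. Compound 3 `CCOC(=O)C#CC(O/C=C/C(=O)OCC)C(C)C` gives 2800 nM in this assay, a higher number, beyond the scatter. Compound 2 `COC(=O)/C=C/OC(C#CC(=O)O)C(C)(C)C` reaches only a limit of this assay, > 100000 nM; it is a limit, not a number (the limit of > 100000 nM in this assay, at which 1 of the 3 values shown sits). Compound 4 `COC(=O)C#CC(C)O/C=C/C(=O)OC` is not yet measured. It differs from compound 1 by hydrogen in place of isopropyl on a saturated chain carbon, two bonds along the chain from an oxygen on an unsaturated carbon and a triple-bonded carbon. For the measured compounds named here, no measured pair of neighbours shows this step, so its size is open. Compound 4 is expected to give a weaker result than compound 1, with an estimated step of a 3.9-fold higher number from compound 1 to compound 4 (0.60 log units; beyond the scatter). The estimate for compound 4 in this assay is 1500 nM, ranging from 400 nM to 6000 nM.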

Compound 4, concentration for 50% growth inhibition: 1700 nM
Beside the measured number, compound 4's estimate is 1.1-fold (0.05 log units) below it, within the range that was stated.
By their numbers in this assay, from the lowest: compound 1; then compounds 4 and 3 (each within the scatter of the next). At a limit, above all of these: compound 2.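

For the compounds shown here, this is the first measured step at this position: hydrogen in place of isopropyl on the saturated chain carbon gives a 4.5-fold higher number from compound 1 to compound 4 (0.65 log units; beyond the scatter) in this assay, so the isobutyl of compound 1 counts for activity, though the step is modest. The change to methyl does not remove growth inhibition, as compound 4 still gives a true number, 1700 nM, and not a limit. No measurement at hand bears on the cause of this step.

From the compounds shown here alone, whether a longer chain or a phenyl ring on this carbon would give a lower number than isobutyl stays open. So does the effect of changing the methyl esters alone.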